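This account rests on a few compounds, and the source may have more. Where it says the series, first, only, none or still open, it means among the compounds named here.

Measured compounds:
- Compound 1, `CCCCCc1cc(=O)c2ccc(O)cc2o1`: in an assay on isolated protein for inhibition of Polyunsaturated fatty acid lipoxygenase ALOX15B (Homo sapiens) (on this read-out lower numbers stand for stronger inhibition and higher numbers for weaker inhibition), compound 1 gives > 100000 nM.
- Compound 2, `CC(C)Cc1oc2ccccc2c(=O)c1O`: in this assay compound 2 gives > 100000 nM.

Neither of these is a measured number. The value of compound 1 is a limit of the assay. The value of compound 2 is likewise a limit of the assay. Both results therefore sit at one and the same point: the limit of > 100000 nM in this assay, at which 2 of the 2 values shown sit. Compound 2 thus stands where the only other measured compound stands, at the edge of what the assay can report, and no difference between the two can be read from the numbers shown.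

Among the measured compounds shown here, compound 3, `CCCCCc1oc2ccccc2c(=O)c1O`, keeps the core of compound 2 and changes only one group: butyl in place of isopropyl on a saturated chain carbon bound to an aromatic carbon. For the measured compounds named here, no step between measured compounds is available to say what such a change does here. Given that compound 2 reaches only the limit > 100000 nM, the expected step is a number no higher from compound 2 to compound 3 (the limit leaves the size open), nothing beyond the usual scatter. Compound 3 is expected at 100000 nM, with a range from 30000 nM to 300000 nM, and most likely reported again only as a limit.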

Compound 3, half-maximal inhibitory concentration: > 100000 nM
Compound 3 ended at the assay's limit; the forecaster's own chance of this, stated with the estimate: 85%; the middle value lies on the limit itself.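

No step can be read from compound 2 to compound 3, since both results are limits of the assay and not measured numbers: the limit of > 100000 nM in this assay, at which 3 of the 3 values shown sit.

The compounds shown leave open how strongly any of them acts in this assay, and whether butyl in place of isopropyl changes that at all.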